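Extending an alkyl group on a hydroxypyridinone core

The source may hold more compounds than are shown below. What is called first, only, known or untested is meant among the compounds shown, and "the series" means these compounds.

Of the compounds shown here, three have been measured in a physicochemical assay for acid dissociation, read by spectrophotometry. Compound 1 `O=c1ccn(CCN2CCCCC2)c(CO)c1O` gives 9.24. Compound 3 `CC(O)c1c(O)c(=O)ccn1CCN1CCCCC1` differs from compound 1 by the change (methyl in place of hydrogen on a saturated chain carbon bound to an aromatic carbon and an oxygen on a saturated carbon). Compound 3 gives 8.73, so this assay reads a number 0.51 log units lower from compound 1 to compound 3 (beyond the scatter). Compound 2 `Cc1c(O)c(=O)ccn1CCN(C)C` gives 9.58, the highest of the three numbers; the difference between the core of compound 2 and the core of compound 1 is not broken down here.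

Compound 4 `CCc1c(O)c(=O)ccn1CCN(C)C` has not yet been measured. It differs from compound 2 by the change (methyl in place of hydrogen on a saturated chain carbon bound to an aromatic carbon). This is the same kind of change as the one from compound 1 to compound 3, the only other such change among the compounds shown. The two places are not identical, however: in compound 1 the carbon that takes the methyl is bound to an aromatic carbon and an oxygen on a saturated carbon, while in compound 2 it is bound to an aromatic carbon only.

Within the data shown here, because the one measured example, compound 1 to compound 3, gave a number 0.51 log units lower from compound 1 to compound 3 (beyond the scatter), a step in the same direction is expected from compound 2 to compound 4, but a smaller one, since the place differs; the expected step is a number 0.13 log units lower from compound 2 to compound 4 (within the scatter). Compound 4 is accordingly estimated at 9.45, with a plausible range from 9.15 to 9.8.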

Compound 4, acid dissociation constant: 9.58
Compound 4: middle estimate off by 0.13 log units, on the low side, within the range that was stated.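

In this assay, methyl in place of hydrogen on a saturated chain carbon bound to an aromatic carbon gives no change at the digits printed from compound 2 to compound 4 (within the scatter), while the same kind of change, on a carbon that also carries an oxygen, gives a number 0.51 log units lower from compound 1 to compound 3 (beyond the scatter). The shift seen on the core of compound 1 therefore did not carry over to the core of compound 2, which shows that this change cannot be treated as a fixed correction to be added to any compound in the series. Among these compounds, it does not show which structural difference separates the two results, since the two pairs differ both at the carbon that takes the methyl and elsewhere in the molecule, and with only one pair on each side no general rule can be drawn, while nothing measured here explains the contrast.

The compounds shown leave open whether a longer chain, such as propyl, would read like the ethyl group of compound 4. They also leave open whether an amine in place of the oxygen on that carbon would follow the pair ending in compound 3 or the pair ending in compound 4.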